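Extending the peptide of a weak hydroxamate inhibitor

The source may report more compounds than this note shows. Statements on the series, on what has been measured and on what is new or still open speak of the compounds shown alone.

Compound 1 `CNC(=O)[C@H](CCC(N)=O)NC(=O)[C@H](CC(=O)O)CC(=O)NO` gives 68000 nM in an assay on isolated protein for inhibition of bone morphogenetic protein 1 (Homo sapiens); on this read-out higher numbers stand for weaker inhibition and lower numbers for stronger inhibition.
Compound 2 `CC[C@H](C)[C@H](NS(=O)(=O)c1ccc(Br)c(Br)c1)C(=O)N[C@@H](CNC(=O)OCc1ccccc1)C(=O)NO` gives 26 nM in this assay.
Compound 3 `CC[C@H](C)[C@H](NS(=O)(=O)c1cc(C)c(Cl)cc1C)C(=O)N[C@@H](CNC(=O)OCc1ccccc1)C(=O)NO` gives 67 nM in this assay.

Of the three measured compounds, compound 1 stands at the highest number, with compound 3 nearer to it and compound 2 furthest away; both of those gaps lie beyond the scatter, so compound 1 is the weakest inhibitor of the set. Compound 4 `CNC(=O)C1CCCN1C(=O)[C@H](CCC(N)=O)NC(=O)[C@H](CC(=O)O)CC(=O)NO` differs from it in one place: 2-(methylcarbamoyl)pyrrolidin-1-yl in place of methylamino on a carbonyl carbon. Going by the values given here, the only measured step, a 2.6-fold higher number from compound 2 to compound 3 (0.41 log units; beyond the scatter), concerns an aryl group on a sulfonyl sulfur in a different scaffold and offers no guidance on lengthening the peptide chain of compound 1. Among the compounds with values here, with no directly relevant step, the expectation for compound 4 rests on compound 1 alone and on the assumption that a larger peptide may bind somewhat more tightly. Compound 4 is therefore expected to improve only modestly, by a 1.9-fold lower number from compound 1 to compound 4 (0.29 log units; within the scatter). The estimate for compound 4 is 35000 nM, within 7000 nM to 180000 nM.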

Compound 4, half-maximal inhibitory concentration: 22000 nM
Estimate against measurement, compound 4: 1.6-fold (0.20 log units) above; the measured number falls inside the stated range.
By their numbers in this assay, from the lowest: compound 2; then compound 3; then compound 4; then compound 1.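

At the carbonyl carbon carrying methylamino in compound 1, the chain can be lengthened without loss in this assay: replacing methylamino with 2-(methylcarbamoyl)pyrrolidin-1-yl gives a 3.1-fold lower number from compound 1 to compound 4 (0.49 log units; beyond the scatter). Going by these compounds alone, this is the first measured change at this end of the peptide, as the earlier step concerned only the aryl group on a sulfonyl sulfur in a different scaffold. The gain is real but modest, and nothing measured here explains why this change shifts the number.

Within the data shown here, the single step cannot separate the contribution of the five-membered ring from that of the added methylcarbamoyl group. It also leaves open how a piperidine ring, or a carboxylic acid in place of the methylcarbamoyl group, would behave at this position.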